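Methyl on the cyclobutane ring: rat microsomal clearance

The source may hold more compounds than are shown below. What is called first, only, known or untested is meant among the compounds shown, and "the series" means these compounds.

Compound 2 `O[C@H](c1ccccn1)[C@]1(c2cccc(C(F)(F)F)c2)C[C@H](O)C1` gives 183 mL/min/kg in an ADME assay on liver for metabolic stability, with Liver microsome (Rattus norvegicus) as the target, read by LC-MS, using microsomes, with a stated time of 5 h; on this read-out higher numbers stand for fast clearance and lower numbers for slow clearance. Compound 1 `C[C@]1(O)C[C@](c2cccc(C(F)(F)F)c2)([C@H](O)c2ccccn2)C1` gives 66.7 mL/min/kg. The change from compound 2 to compound 1 is methyl in place of hydrogen on a saturated ring carbon, and it produced a 2.7-fold lower number from compound 2 to compound 1 (0.44 log units; beyond the scatter). Compound 3 `O[C@H](c1ccccn1)[C@]1(c2ccc(C(F)(F)F)cc2)C[C@@H](O)C1` gives 50 mL/min/kg; how its core differs from that of compound 2 is not broken down here, beyond the two holding the same atoms joined differently. Compound 4 `C[C@]1(O)C[C@@](c2ccc(C(F)(F)F)cc2)([C@H](O)c2ccccn2)C1` has not yet been measured in this assay. From compound 3 to compound 4 the change is methyl in place of hydrogen on a saturated ring carbon, the same change as from compound 2 to compound 1. On the strength of that earlier step, the step from compound 3 to compound 4 is expected to be about a 2.3-fold lower number from compound 3 to compound 4 (0.36 log units; beyond the scatter), though a somewhat smaller movement would not surprise. Compound 4 is therefore estimated at 22 mL/min/kg, with a likely range of 10 mL/min/kg to 45 mL/min/kg.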

Compound 4, clearance: 150 mL/min/kg
Beside the measured number, compound 4's estimate is 6.8-fold (0.83 log units) below it; the measured number lies above the stated range.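

In this assay, methyl in place of hydrogen on a saturated ring carbon gives a 3.0-fold higher number from compound 3 to compound 4 (0.48 log units; beyond the scatter), so the earlier step does not carry over to this core. The two steps run in opposite directions: the same change on two cores in this assay, a 2.7-fold lower number (0.44 log units; beyond the scatter) from compound 2 to compound 1 and a 3.0-fold higher number (0.48 log units; beyond the scatter) from compound 3 to compound 4, 8.2-fold (0.92 log units) apart, beyond the scatter of two such steps. Among the compounds shown here, this shows that, for these two pairs, the outcome of the change depends on the core, but it does not show which difference between the cores sets the direction, as they hold the same atoms joined differently and only two pairs are available.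

From the compounds shown here alone, whether ethyl or an amine on the same ring carbon would split the two cores in the same way remains open. Also open, going by these compounds, is whether any other core would follow either direction.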